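The source may hold more compounds than are shown below. What is called first, only, known or untested is meant among the compounds shown, and "the series" means these compounds.

Working notes on the spiro series. Compound 1 `O=C(CN1CN(c2ccccc2)C2(CCN(C(=O)c3ccc(C4CCCCC4)cc3)CC2)C1=O)N1CCC(CO)CC1` gives 1100 nM in an assay on HEK293 cells for displacement of a labelled ligand from NPC1-like intracellular cholesterol transporter 1 (Homo sapiens); on this read-out lower numbers stand for stronger inhibition and higher numbers for weaker inhibition. Compound 2 `CC(C)(C)c1ccc(C(=O)N2CCC3(CC2)C(=O)N(CC(=O)NCCN)CN3c2ccccc2)cc1` gives 7000 nM, the second highest of the three numbers: compound 3 `O=C(CN1CN(c2ccccc2)C2(CCN(C(=O)c3ccc(C4CCCCC4)cc3)CC2)C1=O)NCO` gives 8300 nM, within the scatter of compound 2, while compound 1 sits beyond the scatter below it. Within the data shown here, the one step across a single change, a 7.5-fold higher number from compound 1 to compound 3 (0.88 log units; beyond the scatter), swaps a ring-bearing amide group for a small open-chain one on the same carbonyl carbon.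

Compound 4 `CC(C)(C)c1ccc(C(=O)N2CCC3(CC2)C(=O)N(CC(=O)N2CCCC(C(N)=O)C2)CN3c2ccccc2)cc1` differs from compound 2 by 3-carbamoylpiperidin-1-yl in place of (2-aminoethyl)amino on a carbonyl carbon. This runs the opposite way to the change between compound 1 and compound 3, replacing an open chain with a ring on that carbonyl carbon, so a lower number is expected, of the order of a 4.7-fold lower number from compound 2 to compound 4 (0.67 log units; beyond the scatter). Compound 4 is therefore estimated at 1500 nM, in the range 500 nM to 5000 nM.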

Compound 4, half-maximal inhibitory concentration: 16900 nM
The estimate for compound 4 lay 11-fold (1.05 log units) below the measured number; the measured number lies above the stated range.
By their numbers in this assay, from the lowest: compound 1; then compounds 2 and 3 (each within the scatter of the next); then compound 4.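

On this carbonyl carbon a ring does not by itself bring a lower number in this assay: 3-carbamoylpiperidin-1-yl in place of (2-aminoethyl)amino gives a 2.4-fold higher number from compound 2 to compound 4 (0.38 log units; beyond the scatter). The ring-bearing group of compound 1 held the lower number against the open chain of compound 3, so a ring and an open chain do not rank the same way in the two pairs, which also differ in the rest of the molecule. Nothing on hand accounts for this reversal.

Left open is whether the rise follows the ring or its carbamoyl group. An unsubstituted piperidin-1-yl, or a carboxylic acid in place of the carbamoyl group, on this carbonyl carbon would bear on that.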